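The source may report more compounds than this note shows. Statements on the series, on what has been measured and on what is new or still open speak of the compounds shown alone.

Compound 1 `COC/C1=C/C[C@](C)(CCC=C(C)C)/C=C/[C@@H](OC(=O)C=C(C)C)[C@](C)(O)/C=C/C1=O` was examined in a functional assay on A549 cells (Homo sapiens) for antiproliferative activity, read by MTT assay, with a stated time of 48 h (a higher number here means a weaker inhibitor, a lower number a stronger inhibitor), where compound 1 gives 3950 nM. Two close relatives were measured the same way: compound 2 `CC(=O)O[C@]1(C)/C=C/C(=O)/C(CO)=C\C[C@](C)(CCC=C(C)C)/C=C/[C@H]1OC(=O)C=C(C)C` gives 3150 nM in this assay, and compound 3 `CC(C)=CCC[C@]1(C)/C=C/[C@@H](OC(=O)C=C(C)C)[C@](C)(O)/C=C/C(=O)/C(C[Si](c2ccccc2)(c2ccccc2)C(C)(C)C)=C\C1` gives 13000 nM. Among these three numbers compound 1 stands second highest; its value and that of compound 2 lie within the usual scatter of one another, whereas compound 3 sits at a higher number, beyond that scatter. Compound 4 `CC(C)=CCC[C@]1(C)/C=C/[C@@H](OC(=O)C=C(C)C)[C@](C)(O)/C=C/C(=O)/C(COC(=O)c2ccc([N+](=O)[O-])cc2)=C\C1` differs from compound 1 in one place: (4-nitrophenyl)carbonyl in place of methyl on an oxygen on a saturated carbon. Going by the values given here, no measured pair here shows this same change, so its size can only be estimated. From compound 1 a small step toward a higher number is expected, perhaps not beyond the scatter: the expected step is a 1.5-fold higher number from compound 1 to compound 4 (0.18 log units; within the scatter). Compound 4 is therefore expected to give 6000 nM, in a range of 2000 nM to 20000 nM.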

Compound 4, half-maximal inhibitory concentration: 1310 nM
For compound 4 the middle estimate is 4.6-fold (0.66 log units) above the measured one; the measured number lies below the stated range.
By their numbers in this assay, from the lowest: compound 4; then compounds 2 and 1 (each within the scatter of the next); then compound 3.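

In this assay, putting (4-nitrophenyl)carbonyl in place of methyl on this oxygen gives a 3.0-fold lower number from compound 1 to compound 4 (0.48 log units; beyond the scatter) and so shows that this place accepts a much larger group, one with an aromatic ring, without a move toward a higher number. The change also moves the number downward by more than the scatter. Nothing at hand gives a reason for this step.

The compounds shown leave open whether the carbonyl or the 4-nitrophenyl ring carries the step. A plain benzoyl on this oxygen, or an amine in place of the oxygen, would test this.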